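A few compounds are considered here, and "the series" means these few. Any claim that something is new, unique, unknown or untested is made for them only; others in the source may bear on it.

Compound 2, `COc1cc(OCc2csc(-c3ccc(C(F)(F)F)cc3)n2)c2cc(-c3cn4nc(OC)sc4n3)oc2c1`, is paired here with compound 1, `COc1cc(OCc2csc(-c3ccc(C(=O)O)cc3)n2)c2cc(-c3cn4nc(OC)sc4n3)oc2c1`. In an ADME assay on microsomes from liver (Homo sapiens) for metabolic stability (on this read-out lower numbers stand for a shorter-lived compound and higher numbers for a longer-lived compound), compound 1 reaches a value that is a limit of the assay, > 2 h. In this assay compound 2 likewise reaches a limit of the assay, > 2 h. The step that the two limits leave unreadable from compound 1 to compound 2 is therefore unreadable in size, and what the two results share is the limit of > 2 h in this assay, at which 2 of the 2 values shown sit. Compound 3, `COc1cc(OCc2csc(-c3ccc(S(C)(=O)=O)cc3)n2)c2cc(-c3cn4nc(OC)sc4n3)oc2c1`, differs from compound 2 in one place: methylsulfonyl in place of trifluoromethyl on an aromatic carbon. For the measured compounds named here, no measured step tells how this change bears on this assay; the single comparison known sits at the limit on both sides, so it sets neither size nor direction. In this assay compound 3 is therefore expected to show a step of only a step that the limit leaves unreadable from compound 2 to compound 3. The half-life of compound 3 in this assay is estimated at 3 h, within a range from 1.2 h to 8 h.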

Compound 3, half-life: 1.22 h
Compound 3: middle estimate off by 2.5-fold (0.39 log units), on the high side; the range from low to high includes it.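

Methylsulfonyl on this aromatic carbon, para to a large group, gives the first half-life at this position in this assay that reads as a number rather than a limit: compound 3 gives 1.22 h. Methylsulfonyl in place of trifluoromethyl gives an at least 1.6-fold lower number from compound 2 to compound 3 (0.21 log units; that floor lies within the scatter), and methylsulfonyl in place of carboxy gives an at least 1.6-fold lower number from compound 1 to compound 3 (0.21 log units; that floor lies within the scatter). Each step is only a floor taken from a limit, and the step between the other two compounds cannot be read; those two compounds share that limit: the limit of > 2 h in this assay, at which 2 of the 3 values shown sit.

As far as these compounds go, the true size of both steps remains open, as does the true half-life of compound 1 and of compound 2. Also open, from the compounds shown here alone, is whether a nitrile or a primary amine at this position would reach the limit or give a readable half-life.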